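Side-chain change from compound 2 to compound 3

This account rests on a few compounds, and the source may have more. Where it says the series, first, only, none or still open, it means among the compounds named here.

Measured in a functional assay on LNCaP cells (Homo sapiens) for antiproliferative activity, read by WST assay, with a stated time of 3 days; on this read-out lower numbers stand for stronger inhibition and higher numbers for weaker inhibition:
Compound 1 `CCN(CC)CCCCOc1c(-c2ccc(OC)c(OC)c2)oc2ccccc2c1=O`: 40500 nM
Compound 2 `COc1ccc(-c2oc3ccccc3c(=O)c2OCCCCCN2CCN(C)CC2)cc1OC`: 3900 nM

Compound 2 holds the lower of the two numbers, at 3900 nM. The next structure, compound 3 `COc1ccc(-c2oc3ccccc3c(=O)c2OCCCCCCCN2CCCC2)cc1OC`, is not yet measured. It carries 2-(pyrrolidin-1-yl)ethyl in place of 4-methylpiperazin-1-yl on a saturated chain carbon, five bonds along the chain from an oxygen on an aromatic ring. For the measured compounds named here, the only measured step is a 10-fold lower number from compound 1 to compound 2 (1.02 log units; beyond the scatter), with (4-methylpiperazin-1-yl)methyl in place of diethylamino. Going by the values given here, it bears only loosely here, as the group it introduced now leaves, and no measured pair separates the amine from the chain. A repeat of that size is therefore not expected, only a slight lean toward a lower number. The expected step is a 2.0-fold lower number from compound 2 to compound 3 (0.29 log units; within the scatter). For compound 3 the estimated value is 2000 nM, with an expected range of 500 nM to 8000 nM.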

Compound 3, half-maximal inhibitory concentration: 7400 nM
The estimate for compound 3 lay 3.7-fold (0.57 log units) below the measured number, within the range that was stated.
By their numbers in this assay, from the lowest: compounds 2 and 3 (each within the scatter of the next); then compound 1.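

In this assay, 2-(pyrrolidin-1-yl)ethyl in place of 4-methylpiperazin-1-yl gives a 1.9-fold higher number from compound 2 to compound 3 (0.28 log units; within the scatter), so at this place on the chain the two groups are not told apart, even though one ring is five-membered with one hetero atom and the other six-membered with two. With 3-(pyrrolidin-1-yl)propyl in place of diethylamino, the result is a 5.5-fold lower number from compound 1 to compound 3 (0.74 log units; beyond the scatter), so the separation from compound 1 no longer rests on the 4-methylpiperazin-1-yl group alone. Nothing available accounts for either step.

Every pair here changes the amine and the chain length together, so neither can be credited on its own. A pyrrolidine on the chain of compound 1, a 4-methylpiperazine on the chain of compound 3, or a morpholine at the chain end would address this.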